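The compounds below may be only part of what the source reports. "The series", "measured", "known", "first", "only" and "open" are said of these compounds alone.

Of the compounds shown here, three built on a shared framework have been tested in a functional assay on OVCAR-3 cells (Homo sapiens) for antiproliferative activity, read by MTT assay, with a stated time of 24 h; on this read-out lower numbers stand for stronger inhibition and higher numbers for weaker inhibition. Compound 1 `O=c1[nH]cc(S(=O)(=O)Nc2ccccc2-c2cn(-c3ccccc3Cl)nn2)c(=O)[nH]1` gives 3170 nM in this assay. Compound 2 `O=c1[nH]cc(S(=O)(=O)Nc2ccccc2-c2cn(-c3cccc(Cl)c3)nn2)c(=O)[nH]1` carries a single change relative to compound 1, namely (3-chlorophenyl in place of 2-chlorophenyl on an aromatic nitrogen), and in this assay compound 2 gives 2180 nM. That step, a 1.5-fold lower number from compound 1 to compound 2 (0.16 log units; within the scatter), is small. Compound 3 `O=c1[nH]cc(S(=O)(=O)Nc2ccc(-c3cn(-c4ccccc4Cl)nn3)cc2)c(=O)[nH]1` rests on a different core; the difference between the two cores is not broken down here. In this assay compound 3 gives 4270 nM, the highest of the three numbers, although its gaps to compound 1 and compound 2 both stay within the usual scatter, so no order can be read from them.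

Compound 4 `O=c1[nH]cc(S(=O)(=O)Nc2ccc(-c3cn(-c4cccc(Cl)c4)nn3)cc2)c(=O)[nH]1` has not yet been measured. It arises from compound 3 by the same change that turns compound 1 into compound 2, placed in the same position: 3-chlorophenyl in place of 2-chlorophenyl on an aromatic nitrogen. For compound 4 a step of similar size is expected, a 1.5-fold lower number from compound 3 to compound 4 (0.17 log units; within the scatter), because the earlier pair showed a 1.5-fold lower number from compound 1 to compound 2 (0.16 log units; within the scatter). Compound 4 is therefore estimated at about 2900 nM in this assay, expected to lie between 1500 nM and 6000 nM.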

Compound 4, half-maximal inhibitory concentration: 2750 nM
Beside the measured number, compound 4's estimate is 1.1-fold (0.02 log units) above it; low and high end bracket the measured number.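

Repeating the swap of 2-chlorophenyl for 3-chlorophenyl on the second core in this assay gives a 1.6-fold lower number from compound 3 to compound 4 (0.19 log units; within the scatter), and this step can be set directly beside the one on the first core: the same change on two cores in this assay, a 1.5-fold lower number (0.16 log units; within the scatter) from compound 1 to compound 2 and a 1.6-fold lower number (0.19 log units; within the scatter) from compound 3 to compound 4, 1.1-fold (0.03 log units) apart, within the scatter of two such steps. The two cores therefore agree, but each step is itself within the scatter, so what carries across is the lack of any clear effect from this swap, not a real difference between the two chlorophenyl groups. Two pairs and a single change also cannot show that other changes would transfer equally well between these cores, or that this one would transfer to a further core.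

From the compounds shown here alone, all four compounds carry a chlorophenyl group on the aromatic nitrogen, so it remains open whether 4-chlorophenyl, an unsubstituted phenyl or a short chain ending in an amine would shift the number beyond the scatter. A group of that kind, tested on both cores, would also be a stricter test of transfer, since a step well beyond the scatter could be compared more clearly.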